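This account rests on a few compounds, and the source may have more. Where it says the series, first, only, none or still open, it means among the compounds named here.

Compound 1 `OC1CCCN(c2nc(-c3ccccn3)nc3c2CN(Cc2ccccc2)CC3)C1` gives 2800 nM in an assay on FRT cells with Cystic fibrosis transmembrane conductance regulator variant F508del (Homo sapiens) as the target, read by fluorescence, with a stated time of 25 min; on this read-out higher numbers stand for an effect only at larger amounts of compound and lower numbers for an effect already at smaller amounts.
Compound 2 `NC(=O)C1CCN(c2nc(-c3ccccn3)nc3c2CN(Cc2ccccc2)CC3)CC1` gives 1400 nM in this assay.
Compound 3 `COc1ccc(CN2CCc3nc(-c4ccccn4)nc(N4CCC(C(N)=O)CC4)c3C2)cc1` gives 3500 nM in this assay.

Among these three numbers compound 3 stands highest. Its nearest neighbour is compound 1, whose value lies within the scatter of its own, so no order between those two can be claimed. Its furthest is compound 2: the step of a 2.5-fold higher number from compound 2 to compound 3 (0.40 log units; beyond the scatter) is beyond the scatter, and it arises from a methoxy in place of hydrogen on an aromatic carbon. The other measured step, a 2.0-fold lower number from compound 1 to compound 2 (0.30 log units; within the scatter), exchanges one ring amine for another and stays within the scatter.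

Compound 4 `COc1ccc(CN2CCc3nc(-c4ccccn4)nc(NCCCn4ccnc4)c3C2)cc1` has not yet been measured in this assay. It differs from compound 3 by (3-(1H-imidazol-1-yl)propyl)amino in place of 4-carbamoylpiperidin-1-yl on an aromatic carbon. Among the measured compounds shown here, no measured step covers this kind of exchange. The nearest analogy is the amine swap a 2.0-fold lower number from compound 1 to compound 2 (0.30 log units; within the scatter), which was within the scatter, but that compared two ring amines and says nothing about an open-chain amine carrying an imidazole. The expectation for compound 4 is therefore a step of no change at the digits printed from compound 3 to compound 4 (within the scatter) that is not beyond the scatter, with wide uncertainty in either direction. Compound 4 is estimated at 3500 nM, with a range from 1000 nM to 12000 nM.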

Compound 4, half-maximal effective concentration in the Cystic fibrosis transmembrane conductance regulator assay: 200 nM
Beside the measured number, compound 4's estimate is 18-fold (1.24 log units) above it, and the stated range ends above it.
By their numbers in the Cystic fibrosis transmembrane conductance regulator assay, from the lowest: compound 4; then compounds 2, 1 and 3 (each within the scatter of the next, the first and the last beyond it).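

In the Cystic fibrosis transmembrane conductance regulator assay, compound 3 gives 3500 nM and compound 4 gives 200 nM; the step of an 18-fold lower number from compound 3 to compound 4 (1.24 log units; beyond the scatter) shows that this position, next to the ring nitrogen, can respond strongly to the group it carries, whereas the earlier exchange between two ring amines, a 2.0-fold lower number from compound 1 to compound 2 (0.30 log units; within the scatter), showed no change beyond the scatter; here a six-membered non-aromatic ring with its carboxamide gives way to an open chain ending in a five-membered aromatic ring, while the heavy-atom count stays the same. Among the compounds shown here, in a physicochemical assay for solubility, read by HPLC, with a stated time of 24 h, at pH 7.4, tested at 250 uM (on this read-out higher numbers stand for higher solubility and lower numbers for lower solubility), compound 3 gives 224000 nM and compound 4 gives 217000 nM, and the same exchange gives a 1.0-fold lower number from compound 3 to compound 4 (0.01 log units; within the scatter), so the large step in the Cystic fibrosis transmembrane conductance regulator assay has no counterpart in solubility. Nothing available explains why this exchange has so large an effect.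

The compounds shown do not separate the contributions of the imidazole, the propyl chain and the amino nitrogen, so it remains open whether a shorter ethyl chain, a longer butyl chain or a pyrazole or phenyl ring at the chain end would hold the number of compound 4. On these data alone, it is also open how an unsubstituted benzyl group in place of the 4-methoxybenzyl group would behave alongside the (3-(1H-imidazol-1-yl)propyl)amino group.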